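Phenyl group exchange on the shared core: working notes

The source may report more compounds than this note shows. Statements on the series, on what has been measured and on what is new or still open speak of the compounds shown alone.

compound 1 `COC1=C(C)C(=O)/C(=C(O)/C=C/c2ccc(O)cc2)C(=O)C1(C)C` gives 3.8 ug/mL
compound 2 `COC1=C(C)C(=O)/C(=C(O)/C=C/c2c(C)cccc2C)C(=O)C1(C)C` gives 7.1 ug/mL

In a functional assay on KB cells (Homo sapiens) for cytotoxicity (on this read-out lower numbers stand for an effect already at smaller amounts and higher numbers for an effect only at larger amounts of compound), compound 2 at 7.1 ug/mL stands within the scatter of compound 1, so no order can be read from the pair. Next comes compound 3 `C=Cc1ccccc1/C=C/C(O)=C1/C(=O)C(C)=C(OC)C(C)(C)C1=O` with the change 2-vinylphenyl in place of 2,6-dimethylphenyl on a double-bonded chain carbon bound to a double-bonded chain carbon at the same place. Among the compounds with values here, one measured step bears on this, the exchange of 4-hydroxyphenyl for 2,6-dimethylphenyl at that place: a 1.9-fold higher number from compound 1 to compound 2 (0.27 log units; within the scatter) and so no real shift. Within the data shown here, no measured compound carries a vinyl group, which leaves this a thin basis. In this assay no step beyond the scatter is therefore expected. The estimated step is a 1.2-fold lower number from compound 2 to compound 3 (0.07 log units; within the scatter) and nothing more. For compound 3 the estimated value is 6 ug/mL with an expected range from 2.5 ug/mL to 14 ug/mL on this read-out.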

Compound 3, concentration for half-maximal effect: 1.9 ug/mL
Compound 3: middle estimate off by 3.2-fold (0.50 log units), on the high side; measured number outside the range, below it.
By their numbers in this assay, from the lowest: compounds 3, 1 and 2 (each within the scatter of the next, the first and the last beyond it).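

In this assay this place on a double-bonded chain carbon now gives a step beyond the scatter, a 3.7-fold lower number from compound 2 to compound 3 (0.57 log units; beyond the scatter) (modest in size), which the earlier pair did not show; the entering 2-vinylphenyl has the same count of heavy atoms as the leaving 2,6-dimethylphenyl and adds one double bond outside aromatic rings. The exchange of 4-hydroxyphenyl for 2-vinylphenyl stays within the scatter at a 2.0-fold lower number from compound 1 to compound 3 (0.30 log units; within the scatter) and so shows no real shift, which means the place separates only compound 2 and compound 3. Nothing at hand accounts for the step between those two compounds.

Open, from the compounds shown here alone, is whether the lower number of compound 3 goes with the vinyl group itself or with the absence of the second methyl group. Also open, going by these compounds, is how an ethyl group, an amine or a carboxylic acid at this ring would read in this assay.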